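Swapping a Benzothiazolylmethyl Ether for a Quinolinyl Ether

The compounds below may be only part of what the source reports. "The series", "measured", "known", "first", "only" and "open" are said of these compounds alone.

Compound 1 `Cc1nc(COc2ccc(C(O/N=C/C(=O)O)C3CCCCC3)cc2)cs1` gives 380 nM in a functional assay for inhibition of Polyunsaturated fatty acid 5-lipoxygenase (Homo sapiens); a lower number here means a stronger inhibitor, a higher number a weaker inhibitor.
Compound 2 `O=C(O)/C=N/OC(c1ccc(OCc2nc3ccccc3s2)cc1)C1CCCCC1` gives 60 nM in this assay.

Compound 2 holds the lower of the two numbers, separated from compound 1 by the step of a 6.3-fold lower number from compound 1 to compound 2 (0.80 log units; beyond the scatter). Compound 3 `O=C(O)/C=N/OC(c1ccc(Oc2ccc3ccccc3n2)cc1)C1CCCCC1` differs from compound 2 in one place: quinolin-2-yl in place of (1,3-benzothiazol-2-yl)methyl on an oxygen on an aromatic ring. Among the compounds with values here, the single measured step exchanged one ring for another while keeping the linking carbon in place; no step removes that carbon or sets a ring directly on the oxygen, so it bears only loosely on this change. The expected step is therefore small and uncertain, a 1.7-fold higher number from compound 2 to compound 3 (0.22 log units; within the scatter). Compound 3 is estimated at 100 nM, between 20 nM and 600 nM.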

Compound 3, half-maximal inhibitory concentration: 160 nM
Beside the measured number, compound 3's estimate is 1.6-fold (0.20 log units) below it; the range from low to high includes it.
By their numbers in this assay, from the lowest: compound 2; then compound 3; then compound 1.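

In this assay, quinolin-2-yl set directly on the oxygen gives up some of the strength reached with (1,3-benzothiazol-2-yl)methyl, with a 2.7-fold higher number from compound 2 to compound 3 (0.43 log units; beyond the scatter). Yet the same group still improves on (2-methyl-1,3-thiazol-4-yl)methyl, with a 2.4-fold lower number from compound 1 to compound 3 (0.38 log units; beyond the scatter), so a ring system on the oxygen without the linking carbon keeps much of the inhibition. No measurement at hand offers an explanation for either step.

Each step changes the ring and removes the linking carbon together, so the compounds shown cannot separate these two changes. A quinolin-2-ylmethyl group on the same oxygen would address that question.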